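This account rests on a few compounds, and the source may have more. Where it says the series, first, only, none or still open, it means among the compounds named here.

For the measured compounds named here, in a functional assay on CHO cells for agonist activity at Melanocortin receptor 4 (Homo sapiens), read by cAMP accumulation (on this read-out higher numbers stand for an effect only at larger amounts of compound and lower numbers for an effect already at smaller amounts), compound 2 `CC[C@H](NC(C)=O)c1cc(Cl)ccc1C1CCN(C(=O)[C@@H]2CN(C(C)(C)C)C[C@H]2c2ccc(F)cc2Cl)CC1` gives 215 nM, the highest of the three numbers measured so far. Compound 3 `CC[C@H](NC(C)=O)c1cc(Cl)ccc1C1CCN(C(=O)[C@H]2CN(C(C)(C)C)C[C@@H]2c2ccc(Cl)cc2F)CC1` gives 111 nM, which lies within the usual scatter of compound 2. Going by the values given here, compound 1 `CC[C@H](NC(C)=O)c1cc(Cl)ccc1C1CCN(C(=O)[C@@H]2CN(C(C)(C)C)C[C@H]2c2ccc(F)cc2F)CC1` gives 17.9 nM, and the one measured pair that differs in a single place is a 12-fold higher number from compound 1 to compound 2 (1.08 log units; beyond the scatter), a change of chloro in place of fluoro on an aromatic carbon. Compound 4 `CC[C@H](NC(C)=O)c1cc(Cl)ccc1C1CCN(C(=O)[C@@H]2CN(C(C)(C)C)C[C@H]2c2ccc(C(F)(F)F)cc2F)CC1` has not yet been measured. It differs from compound 2 in that (2-fluoro-4-(trifluoromethyl)phenyl in place of 2-chloro-4-fluorophenyl on a saturated ring carbon). Among the compounds with values here, this change brings back the fluoro that compound 1 carries while also introducing a trifluoromethyl group, for which no measured step exists; compound 3 differs from compound 2 in more than one way and its value shows only a number close to compound 2. Because a 12-fold higher number from compound 1 to compound 2 (1.08 log units; beyond the scatter) was large, undoing that chloro is expected to lower the number, though the trifluoromethyl group leaves the outcome uncertain. Compound 4 is therefore estimated at 60 nM, with an expected range of 15 nM to 250 nM. This estimate corresponds to an expected 3.6-fold lower number from compound 2 to compound 4 (0.55 log units; beyond the scatter).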

Compound 4, half-maximal effective concentration: 88.8 nM
For compound 4 the middle estimate is 1.5-fold (0.17 log units) below the measured one, and the stated range covers the measured number.
By their numbers in this assay, from the lowest: compound 1; then compounds 4, 3 and 2 (each within the scatter of the next, the first and the last beyond it).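

In this assay, for the compounds shown here, the step of a 5.0-fold higher number from compound 1 to compound 4 (0.70 log units; beyond the scatter) shows that trifluoromethyl in place of fluoro on this aromatic ring also gives a higher number, a second replacement of a fluoro that does so, after a 12-fold higher number from compound 1 to compound 2 (1.08 log units; beyond the scatter) among the earlier compounds. The whole group change gives a 2.4-fold lower number from compound 2 to compound 4 (0.38 log units; beyond the scatter) and so moves the number down, yet compound 4 carries a 2-fluoro group and still does not return to the number of compound 1. The value at this saturated ring carbon therefore depends on both places of the aromatic ring, not on the chloro alone.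

On these data alone, how much of the step belongs to each of the two changes stays open, and so does whether a nitrile or a methoxy in place of the trifluoromethyl would give a lower number. Nothing measured here gives a reason for these shifts.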